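The source may report more compounds than this note shows. Statements on the series, on what has been measured and on what is new or still open speak of the compounds shown alone.

In an ADME assay on the whole organism for inhibition, with Echinochloa crus-galli var. formosensis as the target, with a stated time of 4 days (a lower number here means a stronger inhibitor, a higher number a weaker inhibitor), compound 2 `CC(C)Nc1nc(Cl)nc(N[C@@H](C)c2ccccc2)n1` gives 11000 nM, the highest of the three numbers recorded. Compound 3 `CC(C)Nc1nc(Cl)nc(N[C@H](C)c2ccccc2)n1` gives 2000 nM, and the step of a 5.5-fold lower number from compound 2 to compound 3 (0.74 log units; beyond the scatter) follows from the fact that compounds 2 and 3 differ only in the configuration as drawn. Compound 1 `CCN(c1nc(Cl)nc(N[C@@H](C)c2ccccc2)n1)C(C)C` gives 229 nM, and the step of a 48-fold higher number from compound 1 to compound 2 (1.68 log units; beyond the scatter) is the largest movement among the measured compounds.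

Compound 4 `CCCN(CC)c1nc(Cl)nc(N[C@@H](C)c2ccccc2)n1` has not yet been measured in this assay. Relative to compound 2 the change is ethyl(propyl)amino in place of isopropylamino on an aromatic carbon, so the nitrogen on the aromatic carbon loses its hydrogen-bond donor, much as in compound 1. The step bearing on this is a 48-fold higher number from compound 1 to compound 2 (1.68 log units; beyond the scatter), which ran in the opposite direction when that nitrogen carried hydrogen instead of ethyl; the step of a 5.5-fold lower number from compound 2 to compound 3 (0.74 log units; beyond the scatter) concerns configuration, which compound 4 shares with compound 2, and does not bear. A large step downward, well beyond the scatter, is therefore expected. Compound 4 is expected to give 300 nM, with a range from 100 nM to 1000 nM. That estimate corresponds to an expected step of a 37-fold lower number from compound 2 to compound 4 (1.56 log units; beyond the scatter).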

Compound 4, half-maximal inhibitory concentration: 282 nM
Compound 4: middle estimate off by 1.1-fold (0.03 log units), on the high side; low and high end bracket the measured number.
By their numbers in this assay, from the lowest: compounds 1 and 4 (each within the scatter of the next); then compound 3; then compound 2.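

In this assay, ethyl(propyl)amino in place of isopropylamino on the aromatic carbon gives a 39-fold lower number from compound 2 to compound 4 (1.59 log units; beyond the scatter), so the large drop seen when compound 1 was compared with compound 2 is not confined to a single group: it recurs with a second amino group whose nitrogen carries no hydrogen. Propyl in place of isopropyl on that nitrogen gives a 1.2-fold higher number from compound 1 to compound 4 (0.09 log units; within the scatter), so with ethyl also on the nitrogen, this assay does not distinguish the straight chain from the branched one. The compounds shown offer no evidence for why removing the hydrogen and enlarging the group go with the lower number.

Still open, on these data alone, is how small or large this group can be, for example dimethylamino, dibutylamino or a morpholine ring. Also open, as far as these compounds go, is whether the configuration of compound 3 would change the number when the nitrogen carries two chains.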